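Moving the ring nitrogen in the pendant pyridine of compound 1

This account rests on a few compounds, and the source may have more. Where it says the series, first, only, none or still open, it means among the compounds named here.

Compound 1, `Cc1cc(-c2cnc(NCc3cccnc3)nc2-c2ccc(C)s2)on1`, is a compound whose core carries a methyl-substituted isoxazole, a methyl-substituted thiophene and an amino-linked pyridinylmethyl group. Going by the values given here, in a physicochemical assay for solubility, with a stated time of 24 h, at pH 3 (a higher number here means a more soluble compound, a lower number a less soluble compound), compound 1 gives 1000 nM, the lower of the two numbers known here. Among the compounds with values here, the only other compound with a number, compound 2, `CC(=O)N1CCC(c2nc(N3CCCC3)ncc2-c2cc(C)no2)CC1`, is built on a related core but carries different groups, and in this assay compound 2 gives 207000 nM. The gap between the two is well beyond the usual scatter, but the two structures differ in several places at once, so nothing about any single change can be read from them.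

The untested compound 3, `Cc1cc(-c2cnc(NCc3ccccn3)nc2-c2ccc(C)s2)on1`, differs from compound 1 in one place only: pyridin-2-yl in place of pyridin-3-yl on a saturated chain carbon bound to a nitrogen on an aromatic ring. Both rings have the same atoms and the same count of donors and acceptors; only the position of the ring nitrogen moves. Within the data shown here, with no comparable pair measured, the size of the step is uncertain; a step of no change at the digits printed from compound 1 to compound 3 (within the scatter) is expected, which amounts to little or no change beyond the scatter. For compound 3 the expected solubility in this assay is 1000 nM, within a range from 300 nM to 3500 nM.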

Compound 3, solubility: 1000 nM
Estimate against measurement, compound 3: no gap at the digits printed; measured number inside the range.
By their numbers in this assay, from the lowest: compounds 1 and 3 (each within the scatter of the next); then compound 2.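

Moving the ring nitrogen gives no change at the digits printed from compound 1 to compound 3 (within the scatter) in this assay and this is the first direct reading at this position: in this measurement, pyridin-2-yl and pyridin-3-yl on a saturated chain carbon bound to a nitrogen on an aromatic ring cannot be told apart. The earlier comparison of compound 1 with compound 2 spanned several differences at once and could say nothing about any single group, whereas this pair isolates the location of the ring nitrogen, with the rest of the molecule held the same. No supporting data bear on why the two compounds read alike, so the result stands as an observation only.

Going by these compounds, what stays open is whether a group of a different kind on the same chain carbon, such as a plain phenyl ring, an aliphatic amine or a carboxylic acid, would read differently from the two pyridine rings. A single pair also cannot show whether the same swap would read alike on a different core or in any other measurement.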